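A bromo for hydroxy swap on compound 2

The compounds below may be only part of what the source reports. "The series", "measured", "known", "first", "only" and "open" are said of these compounds alone.

Measured in a functional assay on DU-145 cells (Homo sapiens) for cytotoxicity; a lower number here means a stronger inhibitor of growth, a higher number a weaker inhibitor of growth:
- compound 1 `COc1ccc(C2=C(c3cc(OC)c(OC)c(OC)c3)CC3CCCN3C2=O)cc1O`: > 100000 nM (a limit of the assay)
- compound 2 `COc1ccc(C2=C(c3ccc(SC)cc3)CC3CCCN3C2=O)cc1O`: 6000 nM

In this assay, within the data shown here, compound 2 gives 6000 nM, the only actual number so far. The reading for compound 1 is only a limit (> 100000 nM). Compound 3 `COc1ccc(C2=C(c3ccc(SC)cc3)CC3CCCN3C2=O)cc1Br` carries bromo in place of hydroxy on an aromatic carbon, ortho to a methoxy group (bromo in place of hydroxy on an aromatic carbon). Among the measured compounds shown here, no measured pair shows this exchange, so the expectation rests on compound 2 at 6000 nM alone, and no change beyond the scatter is expected. The step expected is a 1.2-fold lower number from compound 2 to compound 3 (0.08 log units; within the scatter), with wide uncertainty. For compound 3 the estimated value is 5000 nM, with an expected range from 1200 nM to 30000 nM.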

Compound 3, concentration for 50% growth inhibition: 900 nM
Compound 3: middle estimate off by 5.6-fold (0.74 log units), on the high side, outside the stated range (below it).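

In this assay, bromo in place of hydroxy ortho to a methoxy group gives a 6.7-fold lower number from compound 2 to compound 3 (0.82 log units; beyond the scatter). Among these compounds, compounds 1 and 2 both carry hydroxy here, so compound 3 is the first to show that this position tolerates another group, and that growth inhibition does not depend on the hydroxy, at least in this one pair. Nothing shown here accounts for the size of this step. As far as these compounds go, whether an amine, a chloro or a longer alkoxy chain at this position would act like bromo stays open. So does whether bromo would give a similar step alongside the trimethoxyphenyl group of compound 1.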